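Dropping an Ethyl Group from an Aromatic Ring

The compounds below may be only part of what the source reports. "The series", "measured", "known", "first", "only" and "open" are said of these compounds alone.

Compound 1, `CC(=O)c1cccc(NC2=NCCC3(CCCCC3)S2)c1`: 1.31
Compound 2, `CCc1ccc(NC2=NCCC3(CCCCC3)S2)cc1`: 1.75

Of the compounds shown here, two sharing one core have so far been measured in a physicochemical assay for lipophilicity, at pH 7.4; on this read-out higher numbers stand for higher lipophilicity and lower numbers for lower lipophilicity. Compound 1 gives 1.31, and compound 2 gives 1.75. Of the two numbers, compound 2 stands highest; the gap between it and compound 1 lies beyond the usual scatter of repeated measurements, so the two can be told apart with some confidence.

Compound 3, `c1ccc(NC2=NCCC3(CCCCC3)S2)cc1`, has not yet been measured in this assay. It differs from compound 2 in one place: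

hydrogen in place of ethyl on an aromatic carbon

The ethyl group leaves and a hydrogen enters on an aromatic carbon. Among the measured compounds shown here, no step between two measured compounds shows this kind of change here, so the size of the step has to be judged from general experience: taking two carbons out of a molecule usually lowers lipophilicity by a clear margin, well beyond the scatter.

The step expected from this change, a number 0.95 log units lower from compound 2 to compound 3 (beyond the scatter), is a fall. Compound 3 is therefore estimated at 0.8, with a likely range from 0.4 to 1.2.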

Compound 3, distribution coefficient: 1.69
Estimate against measurement, compound 3: 0.89 log units below; measured number above the stated range.
By their numbers in this assay, from the lowest: compound 1; then compounds 3 and 2 (each within the scatter of the next).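

Hydrogen in place of ethyl on an aromatic carbon, para to a large group, gives a number 0.06 log units lower from compound 2 to compound 3 (within the scatter) in this assay and so leaves the two compounds indistinguishable on this read-out, since repeated measurements of a single compound could differ just as much. Among the compounds shown here, this is the first direct look at this change, and it shows that losing the ethyl group from this position need not produce a step that can be told from the scatter. The second step, from acetyl to hydrogen on an aromatic carbon, gives a number 0.38 log units higher from compound 1 to compound 3 (beyond the scatter) and is a modest one, so at least one group on this ring does separate from hydrogen on this read-out, although nothing available explains the difference between the two steps.

Going by these compounds, whether a longer chain such as butyl, an amine or a carboxylic acid at the position held by ethyl would stay within the scatter of compound 3 remains open. Also open, on these data alone, is whether ethyl and hydrogen would remain indistinguishable at another carbon of the ring or on a different core.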